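Working notes: from compound 1 to compound 3

A few compounds are considered here, and "the series" means these few. Any claim that something is new, unique, unknown or untested is made for them only; others in the source may bear on it.

Measured in a physicochemical assay for lipophilicity, read by HPLC, measured as chromatographic lipophilicity, at pH 7.4; on this read-out lower numbers stand for lower lipophilicity and higher numbers for higher lipophilicity
- compound 1 `CCC(=O)N1CCC(C(=O)N2N=CCC2c2ccccc2)CC1` gives 3.2
- compound 2 `CC(C)(C)C(=O)N1N=CCC1c1cccc(F)c1` gives 5.9

Compound 1 holds the lower of the two numbers, and compound 2 stands higher by a gap beyond the scatter. The unmeasured compound 3 `O=C(c1c[nH]nn1)N1CCC(C(=O)N2N=CCC2c2ccccc2)CC1` carries 1H-1,2,3-triazol-4-yl in place of ethyl on a carbonyl carbon. Among the measured compounds shown here, no measured pair shows a single change, so the expectation rests on the structural change alone. A moderate fall in this assay is expected, probably beyond the scatter. The expected step is a number 0.70 log units lower from compound 1 to compound 3 (beyond the scatter) in size. Compound 3 is estimated at 2.5 (expected range 1.9 to 3.1).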

Compound 3, distribution coefficient: 2
Compound 3: middle estimate off by 0.50 log units, on the high side, and the stated range covers the measured number.
By their numbers in this assay, from the lowest: compound 3; then compound 1; then compound 2.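

Among the compounds shown here, on a carbonyl carbon, 1H-1,2,3-triazol-4-yl in place of ethyl gives the first single-place comparison: in this assay the read-out stands a number 1.20 log units lower from compound 1 to compound 3 (beyond the scatter). Compound 3 now holds the lowest number of the three, so at this place more heavy atoms came with a lower number in this one pair. Nothing on hand explains the step. Open remains whether the step follows the nitrogens of the entering ring or the ring itself: phenyl on the same carbonyl carbon would separate the two. An amine or a carboxylic acid at this place would show how far the number moves with other groups.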